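The source may report more compounds than this note shows. Statements on the series, on what has been measured and on what is new or still open speak of the compounds shown alone.

Compound 1 `O=C(O)CNc1cccc(CNc2cc(C(F)(F)F)cc3[nH]ncc23)c1`: 65%
Compound 2 `FC(F)(F)c1cccc(CNc2cc(C(F)(F)F)cc3[nH]ncc23)c1`: 74%
Compound 3 `O=C(O)c1cccc(CNc2cc(C(F)(F)F)cc3[nH]ncc23)c1`: 94%

In an assay for inhibition of Tryptophan 2,3-dioxygenase (Homo sapiens), with stated times of 10 min and 60 min, tested at 100 uM (a lower number here means a weaker effect, a higher number a stronger effect of the compound at the concentration tested), compound 3 stands highest of the three numbers. Compound 2 is nearest to it, and the step of a number 20 percentage points higher from compound 2 to compound 3 (beyond the scatter) lies beyond the scatter, as does a number 29 percentage points higher from compound 1 to compound 3 (beyond the scatter). By contrast, the step of a number 9 percentage points higher from compound 1 to compound 2 (within the scatter) is within the scatter. Compound 4 `OC1CCCC(Nc2cccc(CNc3cc(C(F)(F)F)cc4[nH]ncc34)c2)C1` changes compound 3 in one place: (3-hydroxycyclohexyl)amino in place of carboxy on an aromatic carbon. Both steps that put carboxy in place of another group raised the number, so removing carboxy is expected to lower it; compound 1, which likewise carries an amino-linked group, gave 65%. Compound 4 is therefore expected to give 62%, between 35% and 85%, an estimated step of a number 32 percentage points lower from compound 3 to compound 4 (beyond the scatter).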

Compound 4, a percentage reported as inhibition, at one concentration (the size of the read-out at that concentration, not a potency): 23%
Compound 4: the middle estimate sits 39 percentage points above what was measured, outside the stated range (below it).
By their numbers in this assay, from the lowest: compound 4; then compounds 1 and 2 (each within the scatter of the next); then compound 3.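

In this assay, this position on the aromatic ring tolerates some groups far better than others: (3-hydroxycyclohexyl)amino brings a number 71 percentage points lower from compound 3 to compound 4 (beyond the scatter) and a number 51 percentage points lower from compound 2 to compound 4 (beyond the scatter). The nitrogen link alone does not set the number, since changing only what it carries gives a number 42 percentage points lower from compound 1 to compound 4 (beyond the scatter). No available evidence explains these drops. From the compounds shown here alone, it remains open whether the loss follows the cyclohexyl ring or its hydroxy group. A plain cyclohexylamino group, or a simple amine, at this position would help separate these possibilities.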